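The source may report more compounds than this note shows. Statements on the series, on what has been measured and on what is new or still open speak of the compounds shown alone.

Compound 2 `O=C1NCCN1c1ccc(S(=O)(=O)Nc2cccc(Br)c2)cc1` gives 77 nM in a functional assay on HT-29 cells (Homo sapiens) for antiproliferative activity, read by sulforhodamine B assay, with a stated time of 48 h (on this read-out lower numbers stand for stronger inhibition and higher numbers for weaker inhibition), and holds the lowest number measured, with compound 3 `COc1cccc(NS(=O)(=O)c2ccc(N3CCNC3=O)cc2)c1` at 120 nM within the scatter of it, while compound 1 `CCc1ccccc1NS(=O)(=O)c1ccc(N2CCNC2=O)cc1` gives 240 nM. The steps of a 3.1-fold lower number from compound 1 to compound 2 (0.49 log units; beyond the scatter) and a 2.0-fold lower number from compound 1 to compound 3 (0.30 log units; within the scatter) both follow the move away from 2-ethylphenyl, whereas a 1.6-fold higher number from compound 2 to compound 3 (0.19 log units; within the scatter) lies within the scatter. Compound 4 `Cc1cccc(NS(=O)(=O)c2ccc(N3CCNC3=O)cc2)c1` differs from compound 2 by methyl in place of bromo on an aromatic carbon. Going by the values given here, the only step that bears on this exchange, a 1.6-fold higher number from compound 2 to compound 3 (0.19 log units; within the scatter), is small, so in this assay no step beyond the scatter is expected, at most a slightly higher number. Compound 4 is therefore estimated at 110 nM, with a range from 55 nM to 220 nM. This estimate corresponds to an expected step of a 1.4-fold higher number from compound 2 to compound 4 (0.15 log units; within the scatter).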

Compound 4, half-maximal inhibitory concentration: 110 nM
The estimate for compound 4 equals the measured number at the digits printed, within the range that was stated.
By their numbers in this assay, from the lowest: compounds 2, 4, 3 and 1 (each within the scatter of the next, the first and the last beyond it).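

At this place, on an aromatic carbon meta to a large group, bromo, methoxy and methyl cannot be told apart in this assay, with a 1.4-fold higher number from compound 2 to compound 4 (0.15 log units; within the scatter) and a 1.1-fold lower number from compound 3 to compound 4 (0.04 log units; within the scatter) both within the scatter. With a 2.2-fold lower number from compound 1 to compound 4 (0.34 log units; beyond the scatter), 3-methylphenyl joins 3-bromophenyl in lying beyond the scatter of 2-ethylphenyl, while 3-methoxyphenyl goes against this by staying within it. No measurement here gives a reason for these steps. As far as these compounds go, whether an amine, a carboxylic acid or a longer chain at this place would also leave the number within the scatter stays open.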